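From 4-methoxyphenyl to 2-methoxyphenyl: a step still unmeasured

The source may hold more compounds than are shown below. What is called first, only, known or untested is meant among the compounds shown, and "the series" means these compounds.

- Compound 1 `COc1cc(/C=C/C(=O)/C=C/c2cccs2)ccc1OCc1cn(CCCCCOc2cc(=O)oc3ccccc23)nn1`: 31%
- Compound 2 `COc1ccc(/C=C/C(=O)/C=C/c2ccc(OCc3cn(CCCCCOc4cc(=O)oc5ccccc45)nn3)c(OC)c2)cc1`: 35%

In a functional assay on HCT-116 cells (Homo sapiens) for inhibition, read by sulforhodamine B assay, with a stated time of 48 h, tested at 50 uM (on this read-out higher numbers stand for more inhibition of growth at the one concentration tested and lower numbers for less inhibition of growth), compound 2 gives 35%, level within the scatter with compound 1 at 31%. Compound 3 `COc1ccccc1/C=C/C(=O)/C=C/c1ccc(OCc2cn(CCCCCOc3cc(=O)oc4ccccc34)nn2)c(OC)c1` has the same atoms as compound 2, joined differently: 2-methoxyphenyl in place of 4-methoxyphenyl on a double-bonded chain carbon bound to a double-bonded chain carbon. For the measured compounds named here, only one measured step bears on this place, and it swaps thiophen-2-yl for 4-methoxyphenyl: a number 4 percentage points higher from compound 1 to compound 2 (within the scatter). Going by the values given here, no compound with 2-methoxyphenyl has been measured yet, so no shift beyond the scatter is expected in this assay. The expected change is a number 2 percentage points lower from compound 2 to compound 3 (within the scatter). Compound 3 is estimated at 33%, within a range of 22% to 45%.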

Compound 3, percent growth inhibition at one concentration: 33%
Compound 3: the middle estimate sits on the measured number at the digits printed; measured number inside the range.
By their numbers in this assay, from the lowest: compounds 1, 3 and 2 (each within the scatter of the next).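

In this assay the change from 4-methoxyphenyl to 2-methoxyphenyl gives a number 2 percentage points lower from compound 2 to compound 3 (within the scatter) and the change from thiophen-2-yl to 2-methoxyphenyl gives a number 2 percentage points higher from compound 1 to compound 3 (within the scatter). So moving the methoxy group around this ring, like exchanging the ring itself, leaves the growth inhibition within the scatter at the single concentration tested. Nothing measured here offers a reason for this result.

On these data alone, whether an amine or a carboxylic acid on this ring would shift the number remains open. So does whether these compounds would differ at other concentrations.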